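Phenyl-for-phenyl swap at the chain carbon of compound 3

A few compounds are considered here, and "the series" means these few. Any claim that something is new, unique, unknown or untested is made for them only; others in the source may bear on it.

Compound 3 `COc1ccccc1Cc1cnc(CCc2ccc(-c3ccccc3C(=O)O)cc2)[nH]1` gives 163 nM in an in vitro functional assay on cells for agonist activity at Bombesin receptor subtype-3 (Mus musculus), read by luminescence and calcium flux (a higher number here means that more compound is needed for the effect, a lower number that less compound is needed), the second highest of the three numbers. Compound 1 `N#Cc1ccc(Cc2cnc(CCc3ccc(-c4ccccc4C(=O)O)cc3)[nH]2)cc1` gives 723 nM, and compound 2 `CC(C)CCc1cnc(CCc2ccc(-c3ccccc3C(=O)O)cc2)[nH]1` gives 10 nM. The measured steps are a 4.4-fold lower number from compound 1 to compound 3 (0.65 log units; beyond the scatter) and a 16-fold higher number from compound 2 to compound 3 (1.21 log units; beyond the scatter), so compound 3 sits nearer compound 1 than compound 2. Compound 4 `O=C(O)c1ccccc1-c1ccc(CCc2ncc(Cc3cccc(Cl)c3)[nH]2)cc1` differs from compound 3 by 3-chlorophenyl in place of 2-methoxyphenyl on a saturated chain carbon bound to an aromatic carbon. Both known steps at that chain carbon bear on it: exchanging one substituted phenyl for another gave a 4.4-fold lower number from compound 1 to compound 3 (0.65 log units; beyond the scatter), whereas exchanging phenyl for isobutyl gave a 72-fold lower number from compound 1 to compound 2 (1.86 log units; beyond the scatter). A phenyl-for-phenyl swap is therefore expected to give a step of modest size at most, a 1.4-fold lower number from compound 3 to compound 4 (0.13 log units; within the scatter), with the direction uncertain. Compound 4 is estimated at 120 nM, range 30 nM to 500 nM.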

Compound 4, half-maximal effective concentration: 31 nM
Compound 4: middle estimate off by 3.9-fold (0.59 log units), on the high side, and the stated range covers the measured number.
By their numbers in this assay, from the lowest: compound 2; then compound 4; then compound 3; then compound 1.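

Exchanging one substituted phenyl for another at this chain carbon can shift the number beyond the scatter, with a 5.3-fold lower number from compound 3 to compound 4 (0.72 log units; beyond the scatter) and a 23-fold lower number from compound 1 to compound 4 (1.37 log units; beyond the scatter), a wider spread among phenyl groups than compound 1 and compound 3 alone showed. The phenyl group of compound 4 also narrows the gap to isobutyl, though a 3.1-fold higher number from compound 2 to compound 4 (0.49 log units; beyond the scatter) still leaves compound 2 with the lowest number of the four. Nothing available accounts for these steps.

The step from 2-methoxyphenyl to 3-chlorophenyl changes both the substituent and the number in its name, so these two contributions remain unseparated. Going by these compounds, how an unsubstituted phenyl, or a longer chain in place of isobutyl, would compare remains open.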